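Thiourea anilinoquinazoline sulfonamides: fluorine placement on the aniline

This account rests on a few compounds, and the source may have more. Where it says the series, first, only, none or still open, it means among the compounds named here.

Measured so far in a functional assay on NCI-H1975 cells (Homo sapiens) for antiproliferative activity, read by MTT assay, with a stated time of 72 h; a lower number here means a stronger inhibitor, a higher number a weaker inhibitor:
compound 1 `COc1ccc(Nc2ncnc3cc(OC)c(OCCCCC(=O)Nc4ccc(S(N)(=O)=O)cc4)cc23)cc1OC` gives 9230 nM
compound 2 `COc1cc2ncnc(Nc3cccc(C)c3)c2cc1OCCCCC(=O)Nc1ccc(S(N)(=O)=O)cc1` gives 32100 nM
compound 3 `NS(=O)(=O)c1ccc(NC(=S)Nc2ccc3ncnc(Nc4ccc(F)c(Cl)c4)c3c2)cc1` gives 15800 nM

Compound 3 stands second highest of the three numbers in this assay. Its gap to compound 1 lies within the scatter, so no order between those two can be read; its gap to compound 2 lies beyond the scatter, compound 2 being the higher. Compound 4 `NS(=O)(=O)c1ccc(NC(=S)Nc2ccc3ncnc(Nc4cccc(Cl)c4F)c3c2)cc1` is not yet measured. It differs from compound 3 in one place: 3-chloro-2-fluorophenyl in place of 3-chloro-4-fluorophenyl on a nitrogen on an aromatic ring. The two have the same atoms, joined differently.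

Within the data shown here, the only measured step, a 3.5-fold higher number from compound 1 to compound 2 (0.54 log units; beyond the scatter), also alters the group on a nitrogen on an aromatic ring, but it swaps 3-methylphenyl for 3,4-dimethoxyphenyl on a different core and bears on the present change only loosely. Among the measured compounds shown here, no measured pair compares 3-chloro-2-fluorophenyl with 3-chloro-4-fluorophenyl. With the same atoms retained and nothing in the series pointing either way, the expectation is for no step beyond the scatter, with a modest shift in either direction possible: a 1.1-fold lower number from compound 3 to compound 4 (0.02 log units; within the scatter). Compound 4 is therefore estimated at 15000 nM in this assay, within a range of 5000 nM to 45000 nM.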

Compound 4, half-maximal inhibitory concentration: 25100 nM
Compound 4: middle estimate off by 1.7-fold (0.22 log units), on the low side; low and high end bracket the measured number.
By their numbers in this assay, from the lowest: compounds 1, 3, 4 and 2 (each within the scatter of the next, the first and the last beyond it).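

In this assay, 3-chloro-2-fluorophenyl in place of 3-chloro-4-fluorophenyl on the nitrogen on an aromatic ring gives a 1.6-fold higher number from compound 3 to compound 4 (0.20 log units; within the scatter), so this rearrangement of the same atoms produces no readable separation between the two compounds on the thiourea-bearing core. Among these compounds, this is the first comparison of two isomeric groups at this place, and the first measured step there that stays within the scatter, whereas a 3.5-fold higher number from compound 1 to compound 2 (0.54 log units; beyond the scatter) on the other core lies beyond it. The data on hand offer no measurement that could explain the result in either direction.

Going by these compounds, both thiourea compounds carry the same chlorine and fluorine atoms on the aniline ring, so it remains open whether a 3-aminophenyl or 3-carboxyphenyl group on the same nitrogen would move the number beyond the scatter of compound 3 in this assay. Also open, on these data alone, is whether a urea in place of the thiourea, with 3-chloro-4-fluorophenyl or 3-chloro-2-fluorophenyl kept constant, would change the reading at all.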